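Metabolic half-life in the series: compound 3 to compound 4

The compounds below may be only part of what the source reports. "The series", "measured", "known", "first", "only" and "open" are said of these compounds alone.

Measured so far: compound 1 `CC(C)CCn1nc(-c2cccs2)c(O)c(C2=NS(=O)(=O)c3cc(OC(C)C(N)=O)ccc3N2)c1=O`, compound 2 `CC(C)CCn1nc(-c2cccs2)c(O)c(C2=NS(=O)(=O)c3cc(OCC#N)ccc3N2)c1=O`, compound 3 `CC(C)CCn1nc(-c2cccs2)c(O)c(C2=NS(=O)(=O)c3cc(NC(=O)C4CC4)ccc3N2)c1=O`.

In an in vitro ADME assay on microsomes from liver (Homo sapiens) for metabolic stability, tested at 5 uM (on this read-out lower numbers stand for a shorter-lived compound and higher numbers for a longer-lived compound), compound 1 gives 0.217 h, compound 2 gives 0.25 h and compound 3 gives 0.0833 h, the lowest of the three; the steps of a 2.6-fold lower number from compound 1 to compound 3 (0.42 log units; beyond the scatter) and a 3.0-fold lower number from compound 2 to compound 3 (0.48 log units; beyond the scatter) both lie beyond the scatter, while a 1.2-fold higher number from compound 1 to compound 2 (0.06 log units; within the scatter) does not.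

Compound 4 `CC(C)CCn1nc(-c2cccs2)c(O)c(C2=NS(=O)(=O)c3cc(-c4cnoc4)ccc3N2)c1=O` carries the change (1,2-oxazol-4-yl in place of (cyclopropylcarbonyl)amino on an aromatic carbon). The steps into compound 3 are the ones that bear on this position, and both pointed downward as the amide entered. With the amide leaving again, a modest upward step a 1.8-fold higher number from compound 3 to compound 4 (0.26 log units; within the scatter) is expected, so compound 4 is estimated at 0.15 h, between 0.06 h and 0.4 h.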

Compound 4, half-life: 0.5 h
Beside the measured number, compound 4's estimate is 3.3-fold (0.52 log units) below it; measured number outside the range, above it.
By their numbers in this assay, from the lowest: compound 3; then compounds 1, 2 and 4 (each within the scatter of the next, the first and the last beyond it).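

Placing 1,2-oxazol-4-yl directly on the aromatic carbon gives the first step upward at this position in this assay: a 6.0-fold higher number from compound 3 to compound 4 (0.78 log units; beyond the scatter) and a 2.3-fold higher number from compound 1 to compound 4 (0.36 log units; beyond the scatter). Against the cyanomethoxy group the change stays inside the scatter, with a 2.0-fold higher number from compound 2 to compound 4 (0.30 log units; within the scatter), so compound 4 and compound 2 cannot be ordered. Nothing measured here accounts for these steps.

Going by these compounds, whether the gain belongs to 1,2-oxazol-4-yl itself or to any directly attached aromatic ring remains open. A phenyl or pyridyl ring at this position would separate the two readings.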